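Geometric Isomer of Compound 3 in a Dopamine Receptor Assay

This account rests on a few compounds, and the source may have more. Where it says the series, first, only, none or still open, it means among the compounds named here.

compound 1: `CO/N=C(/CCN1CCN(c2ccccn2)CC1)c1ccccc1Cl` — 73%
compound 2: `CO/N=C(/CCN1CCN(c2ccccn2)CC1)c1ccccc1C` — 72%
compound 3: `CO/N=C(\CCN1CCN(c2ccccn2)CC1)c1ccc(Cl)cc1` — 87%

Three compounds were tested in a functional assay on HEK293 cells with D(4) dopamine receptor (Homo sapiens) as the target, read by FLIPR; on this read-out lower numbers stand for smaller maximal responses and higher numbers for larger maximal responses. Going by the values given here, compound 1 gives 73% and compound 2 gives 72%; the step of a number 1 percentage points lower from compound 1 to compound 2 (within the scatter) is the only one between neighbours. Compound 3 gives 87%, the highest of the three, beyond the scatter from both compound 1 and compound 2.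

Compound 4 `CO/N=C(/CCN1CCN(c2ccccn2)CC1)c1ccc(Cl)cc1` follows from compound 3: the two compounds have the same atoms and bonds and differ only in configuration as drawn: 1 of 1 stereo elements differ; a double bond is drawn E in compound 3 and Z in compound 4. Among the compounds with values here, no measured step concerns the configuration of the double bond; the single step measured, from chloro to methyl, does not bear on it. With nothing to go on, no step beyond the scatter is expected, but the estimate carries a wide range. Compound 4 is expected to give 80% (between 60% and 100%), a step of a number 7 percentage points lower from compound 3 to compound 4 (within the scatter).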

Compound 4, largest response reached (reported as efficacy), in percent of the reference or control that the assay uses: 68%
For compound 4 the middle estimate is 12 percentage points above the measured one; low and high end bracket the measured number.
By their numbers in this assay, from the lowest: compounds 4, 2 and 1 (each within the scatter of the next); then compound 3.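

In this assay, changing the double bond alone gives a number 19 percentage points lower from compound 3 to compound 4 (beyond the scatter). This step belongs to the configuration of that double bond alone, because of one fact: the fact that compounds 3 and 4 differ only in the configuration as drawn. By contrast, 4-chlorophenyl in place of 2-methylphenyl gives a number 4 percentage points lower from compound 2 to compound 4 (within the scatter), and 4-chlorophenyl in place of 2-chlorophenyl gives a number 5 percentage points lower from compound 1 to compound 4 (within the scatter).

On these data alone, whether the double bond matters as much with 2-chlorophenyl or 2-methylphenyl remains open. So does the effect of an ethoxy group in place of the methoxy group, or of a longer chain to the piperazine-bearing amine.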